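Changing the Aromatic Ring of Compound 1

The compounds below may be only part of what the source reports. "The series", "measured", "known", "first", "only" and "open" are said of these compounds alone.

Of the compounds shown here, two sharing one core have been measured so far. Compound 1 `CCNC(=O)N1CCN(C(=S)SCc2cn(Cc3ccccc3F)nn2)CC1` and compound 2 `CC(C)(C)NC(=O)N1CCN(C(=S)SCc2cn(Cc3ccccc3F)nn2)CC1` differ only at an amide-type nitrogen, where a tert-butyl replaces an ethyl. In a functional assay on EC9706 cells (Homo sapiens) for cytotoxicity, read by MTT assay, with a stated time of 72 h (on this read-out higher numbers stand for weaker inhibition and lower numbers for stronger inhibition), compound 1 gives 23700 nM, and compound 2 gives 87800 nM. Going by the values given here, compound 1 thus stands at the lowest number of the two, and the only measured step is a 3.7-fold higher number from compound 1 to compound 2 (0.57 log units; beyond the scatter). Compound 3 `CCNC(=O)N1CCN(C(=S)SCc2cn(Cc3ccc(OC)cc3)nn2)CC1` keeps the ethyl group of compound 1 and alters a different part of the molecule: 4-methoxyphenyl in place of 2-fluorophenyl on a saturated chain carbon bound to an aromatic nitrogen. Among the compounds with values here, no measured step touches this part, so the single step available, sitting elsewhere, offers no direct guidance on direction or size. With nothing pointing to a change, the expectation is that compound 3 stays close to compound 1, a step of a 1.0-fold higher number from compound 1 to compound 3 (0.01 log units; within the scatter) within the scatter. Compound 3 is therefore estimated at 24000 nM, with a range from 8000 nM to 72000 nM.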

Compound 3, half-maximal inhibitory concentration: > 128000 nM
Compound 3 was reported as a limit (the forecaster's own chance of this, stated with the estimate: 10%); at least 5.3-fold (0.72 log units) between middle value and limit.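

The part of the molecule on the saturated chain carbon bound to an aromatic nitrogen clearly matters in this assay: 4-methoxyphenyl in place of 2-fluorophenyl gives an at least 5.4-fold higher number from compound 1 to compound 3 (0.73 log units; beyond the scatter). Going by these compounds alone, the only earlier step lay at the amide-type nitrogen, so this is the first sign that a second place on the shared core also moves the read-out, here towards weaker inhibition. The result for compound 3 is a limit of the assay and not a number, so the step has a lower bound but no known full size: the limit of > 128000 nM in this assay, at which 1 of the 3 values shown sits.

The compounds shown leave open whether the loss of the fluorine or the arrival of the methoxy group carries this step. Going by these compounds, what a plain phenyl or a pyridyl group would give at this place also remains open.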